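Same aryl swap, a second time, on a methyl core

This account rests on a few compounds, and the source may have more. Where it says the series, first, only, none or still open, it means among the compounds named here.

Of the compounds shown here, three have been measured in an ADME assay on U-937 cells (Homo sapiens) for cytotoxicity, read by MTT assay, with a stated time of 24 h; on this read-out lower numbers stand for higher toxicity in this test and higher numbers for lower toxicity in this test. Compound 1 `Clc1ccc(C(CCn2ccnc2)Oc2ccc(Cl)cc2Cl)cc1` gives 172000 nM. Compound 2 `Clc1ccc(C(CCn2ccnc2)Oc2cc(Cl)cc(Cl)c2)cc1` gives 180000 nM. Compound 3 `Cc1ccc(C(CCn2ccnc2)Oc2ccc(Cl)cc2Cl)cc1` gives 150000 nM. Compound 4 `Cc1ccc(C(CCn2ccnc2)Oc2cc(Cl)cc(Cl)c2)cc1` has not yet been measured in this assay.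

The change 3,5-dichlorophenyl in place of 2,4-dichlorophenyl on an oxygen on a saturated carbon gave a 1.0-fold higher number from compound 1 to compound 2 (0.02 log units; within the scatter). Compound 4 arises from compound 3 by the same change, (3,5-dichlorophenyl in place of 2,4-dichlorophenyl on an oxygen on a saturated carbon), made on a different core: the core of compound 3 differs from that of compound 1 by methyl in place of chloro on an aromatic carbon, a change that gave a 1.1-fold lower number from compound 1 to compound 3 (0.06 log units; within the scatter).

Because compound 1 to compound 2 showed a 1.0-fold higher number from compound 1 to compound 2 (0.02 log units; within the scatter), the same change is expected to leave the number nearly unchanged on the core of compound 3 as well, giving an estimated 1.0-fold higher number from compound 3 to compound 4 (0.01 log units; within the scatter). Compound 4 is therefore expected to give about 155000 nM in this assay, estimated between 90000 nM and 260000 nM.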

Compound 4, half-maximal cytotoxic concentration: 160000 nM
For compound 4 the middle estimate is 1.0-fold (0.01 log units) below the measured one, within the range that was stated.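

In this assay, among the compounds shown here, 3,5-dichlorophenyl in place of 2,4-dichlorophenyl gave a 1.1-fold higher number from compound 3 to compound 4 (0.03 log units; within the scatter), which agrees with the same swap on the core of compound 1: the same change on two cores in this assay, a 1.0-fold higher number (0.02 log units; within the scatter) from compound 1 to compound 2 and a 1.1-fold higher number (0.03 log units; within the scatter) from compound 3 to compound 4, 1.0-fold (0.01 log units) apart, within the scatter of two such steps Methyl in place of chloro on an aromatic carbon gave a 1.1-fold lower number from compound 2 to compound 4 (0.05 log units; within the scatter), and this step also agrees with its earlier counterpart: the same change on two cores in this assay, a 1.1-fold lower number (0.06 log units; within the scatter) from compound 1 to compound 3 and a 1.1-fold lower number (0.05 log units; within the scatter) from compound 2 to compound 4, 1.0-fold (0.01 log units) apart, within the scatter of two such steps Across these four compounds, both changes carry from one core to the other, but each step lies within the scatter, so this shows only that they leave the number nearly unchanged here, not that a change with a real effect would carry over in the same way.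

The compounds shown leave open whether an amine or a carboxylic acid in place of the methyl or chloro on an aromatic carbon would move the number. They also leave open whether the aryl swap would still carry over on such a core.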